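Adding One More Carbon to a Saturated Chain

The compounds below may be only part of what the source reports. "The series", "measured", "known", "first", "only" and "open" are said of these compounds alone.

Going by the values given here, compound 2 `CCCOC(=O)C1=C(C)NC(=S)NC1c1ccsc1` holds the low end of the two numbers measured so far: in an assay on membranes from HeLa cells for displacement of a labelled ligand from adenosine receptor A3 (Homo sapiens), read by scintillation counting, with a stated time of 180 min, tested at 1 uM (on this read-out higher numbers stand for more inhibition at the one concentration tested (going by the name of the read-out) and lower numbers for less inhibition), compound 2 gives 1%. Among the compounds with values here, compound 1 `COC(=O)C1=C(C)NC(=S)NC1c1ccsc1` gives 3% in this assay, so the single measured step, a number 2 percentage points lower from compound 1 to compound 2 (within the scatter), stays within the scatter. Compound 3 `CC1=C(C(=O)OCC(C)C)C(c2ccsc2)NC(=S)N1` differs from compound 2 by methyl in place of hydrogen on a saturated chain carbon bound to two saturated chain carbons. Within the data shown here, the only step that bears on this change is a number 2 percentage points lower from compound 1 to compound 2 (within the scatter), which enlarged the same saturated chain and left the read-out unchanged within the scatter; the present change adds one further carbon to that chain. A step beyond the scatter is therefore not expected, and the estimated step of a number 1 percentage points higher from compound 2 to compound 3 (within the scatter) lies inside it. Compound 3 is expected to give about 2% in this assay, with an estimated range from 0% to 10%.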

Compound 3, a percentage reported as inhibition, at one concentration (the size of the read-out at that concentration, not a potency): 2%
The estimate for compound 3 equals the measured number at the digits printed; low and high end bracket the measured number.
By their numbers in this assay, from the lowest: compounds 2, 3 and 1 (each within the scatter of the next).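

In this assay, the step from propyl to isobutyl gives a number 1 percentage points higher from compound 2 to compound 3 (within the scatter) and so shows that a branch on this saturated chain, like the earlier lengthening, does not move the number beyond the scatter. The larger change taken in one piece gives a number 1 percentage points lower from compound 1 to compound 3 (within the scatter) as well, so it also stays within the scatter, and all three numbers lie close to zero. No measurement at hand offers an explanation for this flat result.

The compounds shown cover only small saturated chains at this position, so a much longer chain, a benzyl group or an amine on the chain remains open. Whether any change elsewhere on the shared core would raise the number also stays unanswered.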